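Swapping the Amide Aryl Group on a Shared Core

The source may report more compounds than this note shows. Statements on the series, on what has been measured and on what is new or still open speak of the compounds shown alone.

Four compounds share one core and differ only in the group carried on the amide nitrogen. Compound 1 `COc1cc(NC(=O)c2cncc(N3CC4CC(C3)N4)c2)cc(OC)c1` carries a dimethoxyphenyl group, and in an assay on cells for displacement of a labelled ligand from Neuronal acetylcholine receptor; alpha3/beta4 (Homo sapiens) (on this read-out higher numbers stand for weaker inhibition and lower numbers for stronger inhibition), compound 1 gives 2000 nM. Compound 2 `O=C(c1cncc(N2CC3CC(C2)N3)c1)N1CCc2ccccc2C1` closes the amide into a bicyclic amine, and in this assay compound 2 gives 21 nM. Compound 3 `O=C(Nc1ccc(F)cc1F)c1cncc(N2CC3CC(C2)N3)c1` carries a 2,4-difluorophenyl group, and in this assay compound 3 gives 50 nM.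

Among the three measured numbers compound 3 stands second highest. Its nearest neighbour is compound 2, whose lower number lies beyond the usual scatter, so compound 2 is the stronger binder of the two. Compound 1 sits far away with a much higher number, also beyond the scatter, making compound 1 the weakest of the three.

Compound 4 `O=C(Nc1cccc(Cl)c1)c1cncc(N2CC3CC(C2)N3)c1` has not been measured. It differs from compound 3 in one place: 3-chlorophenyl in place of 2,4-difluorophenyl on an amide-type nitrogen. Going by the values given here, no measured pair shows this exact exchange, so no measured step guides it. Since both rings are halogen-bearing phenyl groups on the same amide nitrogen, the step is expected to stay within the scatter, and the expected step is a 1.2-fold higher number from compound 3 to compound 4 (0.08 log units; within the scatter). Compound 4 is therefore estimated at 60 nM, with a range from 20 nM to 200 nM.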

Compound 4, inhibition constant: 59 nM
Compound 4: the middle estimate sits 1.0-fold (0.01 log units) above what was measured; the measured number falls inside the stated range.
By their numbers in this assay, from the lowest: compound 2; then compounds 3 and 4 (each within the scatter of the next); then compound 1.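

In this assay, putting 3-chlorophenyl in place of 2,4-difluorophenyl on the amide-type nitrogen gives a 1.2-fold higher number from compound 3 to compound 4 (0.07 log units; within the scatter) and stays within the scatter, so the two compounds cannot be ranked against each other. Going by these compounds alone, this is the first pair here that differs in one place only, and it gives a direct reading at this position: the exchange changes the halogen, the number of halogens on the ring and where they sit, yet no change in binding beyond the scatter can be seen. Nothing shown here bears on why these two groups give numbers this close.

From the compounds shown here alone, a single step cannot separate those three changes, so it remains open whether a phenyl ring with no halogen at all, or a 3-fluorophenyl or 4-chlorophenyl group, would give a number close to these two. Going by these compounds, it is also open how groups of a different kind would fare on this nitrogen, such as a benzyl group, a pyridine ring or a methoxy-bearing phenyl ring with a single methoxy group.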